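The source may report more compounds than this note shows. Statements on the series, on what has been measured and on what is new or still open speak of the compounds shown alone.

Measured so far:
Compound 1, `Oc1ccc(-c2cc(-c3ccsc3)cc(-c3cccc(O)c3)n2)cc1`: 2580 nM
Compound 2, `Oc1cccc(-c2cc(-c3cccnc3)cc(-c3ccccc3O)n2)c1`: 7530 nM

Both were tested in a functional assay on HeLa cells (Homo sapiens) for cytotoxicity, read by CCK-8 assay; a higher number here means a weaker inhibitor, a lower number a stronger inhibitor. Compound 2 stands at the higher of the two numbers; compound 1 sits a good way below it, and that gap is wider than the usual scatter of such measurements, so compound 2 is the weaker of the pair.

Compound 3, `Oc1ccc(-c2cc(-c3cccnc3)cc(-c3cccc(O)c3)n2)cc1`, has not yet been measured. It keeps every atom of compound 2 but joins them differently: 4-hydroxyphenyl in place of 2-hydroxyphenyl on an aromatic carbon.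

For the measured compounds named here, no pair of measured compounds shows this exact swap on its own, so the size of the step rests on a loose comparison. Compound 1 also carries a 4-hydroxyphenyl group and gives the lower number, which points toward a modest drop in the inhibitory concentration for compound 3 rather than a rise. The expected step from compound 2 to compound 3 is a 2.0-fold lower number from compound 2 to compound 3 (0.30 log units; within the scatter). Compound 3 is therefore estimated at 3800 nM, with a plausible range from 1500 nM to 9500 nM.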

Compound 3, half-maximal inhibitory concentration: > 50000 nM
Compound 3 ended at the assay's limit; the forecaster's own chance of this, stated with the estimate: 3%; middle value at least 13-fold (1.11 log units) away from the limit.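

In this assay compound 3 gives > 50000 nM, which is a limit of the assay and not a number: the limit of > 50000 nM in this assay, at which 1 of the 3 values shown sits. Placing 4-hydroxyphenyl instead of 2-hydroxyphenyl on the aromatic carbon next to the ring nitrogen leaves the atoms and the counted donors and acceptors unchanged, yet it gives an at least 6.6-fold higher number from compound 2 to compound 3 (0.82 log units; beyond the scatter), so where the hydroxy group sits on this phenyl ring matters here, not only whether it is present. With the 4-hydroxyphenyl group kept, pyridin-3-yl in place of thiophen-3-yl gives an at least 19-fold higher number from compound 1 to compound 3 (1.28 log units; beyond the scatter), which shows that this second place also has a large effect on the cell read-out.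

Going by these compounds, the true size of both steps stays unknown, since compound 3 gives only a limit, and it is also open whether 2-hydroxyphenyl paired with thiophen-3-yl would give a lower number than either group alone suggests. Nor do these compounds show whether a methoxy group or an amine at the same spot on the phenyl ring would behave like the hydroxy group.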